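Lengthening the linker in a chromone sigma ligand

This account rests on a few compounds, and the source may have more. Where it says the series, first, only, none or still open, it means among the compounds named here.

Two measured chromones frame the question. Compound 1 `O=c1cc(-c2cccnc2)oc2ccc(OCCCCCCN3CCC(O)CC3)cc12` gives 194 nM in an assay on isolated protein (Cavia porcellus) with Sigma non-opioid intracellular receptor 1 (Homo sapiens) as the target, read by radioligand binding; a higher number here means a weaker inhibitor, a lower number a stronger inhibitor. Compound 2 `COc1ccc(-c2cc(=O)c3cc(OCCCCCN4CCC(O)CC4)ccc3o2)cc1`, which carries a methoxyphenyl group and a shorter linker, gives 493 nM in this assay, the higher of the two numbers; the two compounds differ in more than one place, so their gap is only reported, not explained. Compound 3 `COc1ccc(-c2cc(=O)c3cc(OCCCCCCN4CCC(O)CC4)ccc3o2)cc1` keeps everything of compound 2 except that the chain grows by one link: (4-hydroxypiperidin-1-yl)methyl in place of 4-hydroxypiperidin-1-yl on a saturated chain carbon, five bonds along the chain from an oxygen on an aromatic ring. Going by these compounds, no single-step comparison between measured compounds exists here, so the size of the effect is unknown. Compound 1, bearing the longer chain, gives 194 nM, which hints at a lower number for compound 3, but the aryl group also changes. Compound 3 is therefore expected to reach about 300 nM, within 120 nM to 750 nM, a modest step of a 1.6-fold lower number from compound 2 to compound 3 (0.22 log units; within the scatter) that may not exceed the scatter.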

Compound 3, half-maximal inhibitory concentration: 254 nM
Estimate against measurement, compound 3: 1.2-fold (0.07 log units) above; the range from low to high includes it.
By their numbers in this assay, from the lowest: compounds 1, 3 and 2 (each within the scatter of the next, the first and the last beyond it).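

In this assay, growing the chain by one link, with (4-hydroxypiperidin-1-yl)methyl in place of 4-hydroxypiperidin-1-yl, gives a 1.9-fold lower number from compound 2 to compound 3 (0.29 log units; within the scatter), so at this position the change cannot be told apart from repeat-measurement noise. Among these compounds, the first single-place reading of the aryl group, 4-methoxyphenyl in place of pyridin-3-yl on an aromatic carbon, gives a 1.3-fold higher number from compound 1 to compound 3 (0.12 log units; within the scatter), and this step also stays inside the scatter, so neither change alone has a effect that can be resolved here. Nothing shown gives a measured reason for either step.

Going by these compounds, what a longer chain, such as 4-(4-hydroxypiperidin-1-yl)butyl at this place, would do remains open. So does the effect of another amine, such as morpholine, in place of the 4-hydroxypiperidine at the chain end.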